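Amide nitrogen substituent change, compound 2 to compound 3

A few compounds are considered here, and "the series" means these few. Any claim that something is new, unique, unknown or untested is made for them only; others in the source may bear on it.

Among the measured compounds shown here, compound 2 `CCNC(=O)c1cc(Oc2cccc(NC(=S)Nc3cccc(C(F)(F)F)c3)c2)ccn1` is the only member with a number in a functional assay on MDA-MB-231 cells (Homo sapiens) for cytotoxicity, read by MTT assay, with a stated time of 48 h; on this read-out higher numbers stand for weaker inhibition and lower numbers for stronger inhibition; in it compound 2 gives 53100 nM. Compound 1 `CCNC(=O)c1cc(Oc2cccc(NC(=S)Nc3ccc(F)c(F)c3)c2)ccn1` gives only a limit in this assay, > 100000 nM (the limit of > 100000 nM in this assay, at which 1 of the 2 values shown sits). For the measured compounds named here, the one measured step, an at least 1.8-fold lower number from compound 1 to compound 2 (0.27 log units; that floor lies within the scatter), changes the aryl group on the thiourea nitrogen, not the amide side. Compound 3 `O=C(NC1CCCCC1)c1cc(Oc2cccc(NC(=S)Nc3cccc(C(F)(F)F)c3)c2)ccn1` carries cyclohexyl in place of ethyl on an amide-type nitrogen. Going by the values given here, no measured step touches this amide-type nitrogen, so no direction can be read from the data, and a change within the scatter is expected in this assay. Compound 3 is therefore expected at 45000 nM (range 15000 nM to 100000 nM). The expected step is a 1.2-fold lower number from compound 2 to compound 3 (0.07 log units; within the scatter).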

Compound 3, half-maximal inhibitory concentration: > 100000 nM
Compound 3: no number, only a limit; the forecaster's own chance of this, stated with the estimate: 30%; middle value at least 2.2-fold (0.34 log units) away from the limit.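

In this assay, among the compounds shown here, cyclohexyl in place of ethyl on the amide-type nitrogen gives an at least 1.8-fold higher number from compound 2 to compound 3 (0.27 log units; that floor lies within the scatter) and is the first measured step at this position. Compound 3 gives only a limit, so the size of this step remains unfixed and its floor does not clear the scatter. Compound 2 alone has a number among the compounds shown: the limit of > 100000 nM in this assay, at which 2 of the 3 values shown sit.

From the compounds shown here alone, whether methyl or a chain ending in an amine on this nitrogen would give a number in this assay stays open. Also open, going by these compounds, is whether a group larger than ethyl on this nitrogen can give a number at all.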